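The source may report more compounds than this note shows. Statements on the series, on what has been measured and on what is new or still open speak of the compounds shown alone.

Measured so far:
- compound 1, `c1ccc(CNCC2CCN(CCCc3c[nH]c4ccc(-n5cnnc5)cc34)CC2)cc1`: in an assay on CHO cells for displacement of a labelled ligand from 5-hydroxytryptamine receptor 1D (Homo sapiens) (a lower number here means a stronger inhibitor, a higher number a weaker inhibitor), compound 1 gives 1.6 nM
- compound 2, `C[C@@H](NC1CCN(CCCc2c[nH]c3ccc(-n4cnnc4)cc23)CC1)c1ccccc1`: compound 2 gives 0.4 nM
- compound 3, `CN(Cc1ccsc1)C1CCN(CCCc2c[nH]c3ccc(-n4cnnc4)cc23)CC1`: compound 3 gives 1.5 nM

Compound 3 stands second highest of the three numbers. Its nearest neighbour is compound 1, with a 1.1-fold lower number from compound 1 to compound 3 (0.03 log units; within the scatter); its furthest is compound 2, with a 3.8-fold higher number from compound 2 to compound 3 (0.57 log units; beyond the scatter).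

Compound 4, `CN(Cc1ccccc1)CC1CCN(CCCc2c[nH]c3ccc(-n4cnnc4)cc23)CC1`, differs from compound 3 in one place: (benzyl(methyl)amino)methyl in place of methyl((thiophen-3-yl)methyl)amino on a saturated ring carbon. Compound 4 thus carries the benzyl group of compound 1 on a methyl-bearing amine nitrogen like that of compound 3. Going by the values given here, the steps that bear on this change are a 1.1-fold lower number from compound 1 to compound 3 (0.03 log units; within the scatter), which lies within the scatter, and a 4.0-fold lower number from compound 1 to compound 2 (0.60 log units; beyond the scatter), which is modest. The expected step is therefore a 1.2-fold lower number from compound 3 to compound 4 (0.06 log units; within the scatter), which stays within the scatter. Compound 4 is expected to give 1.3 nM, with a range from 0.5 nM to 4 nM.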

Compound 4, half-maximal inhibitory concentration: 0.9 nM
Beside the measured number, compound 4's estimate is 1.4-fold (0.16 log units) above it; the range from low to high includes it.
By their numbers in this assay, from the lowest: compound 2; then compounds 4, 3 and 1 (each within the scatter of the next).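

Placing a methyl on the amine nitrogen gives a 1.8-fold lower number from compound 1 to compound 4 (0.25 log units; within the scatter), which is within the scatter in this assay, so this nitrogen can carry either a hydrogen or a methyl with no clear change in the number. Replacing methyl((thiophen-3-yl)methyl)amino with (benzyl(methyl)amino)methyl gives a 1.7-fold lower number from compound 3 to compound 4 (0.22 log units; within the scatter), also within the scatter, while a 2.3-fold higher number from compound 2 to compound 4 (0.35 log units; beyond the scatter) is a modest step beyond it. No measurement shown explains these steps. Still open, from the compounds shown here alone, is how an ethyl group on that nitrogen, or a hydroxyl or carboxylic acid on the benzene ring, would affect the number.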